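The source may hold more compounds than are shown below. What is called first, only, known or untested is meant among the compounds shown, and "the series" means these compounds.

- Compound 1 `COc1cc(N2CCC(C)(O)CC2)ccc1Nc1nc(O[C@H]2CCOC(C)(C)C2)c2cc[nH]c2n1`: 5300 ng.h/mL
- Compound 2 `CCOc1cc(C(=O)N(C)C)ccc1Nc1nc(O[C@H]2CC[C@@](C)(O)CC2)c2cc[nH]c2n1`: "not determined" (no result reported)

Within the data shown here, in an ADME assay on the whole organism (Rattus norvegicus) for pharmacokinetics, at a dose of 10 mg/kg by the oral route (a higher number here means more compound in the circulation at the dose given, a lower number less compound in the circulation), compound 1 gives 5300 ng.h/mL, and this is the only number available, as compound 2 has no reported result to compare with it. Compound 3 `COc1cc(C(=O)N(C)C)ccc1Nc1nc(O[C@H]2CCOC(C)(C)C2)c2cc[nH]c2n1` carries dimethylcarbamoyl in place of 4-hydroxy-4-methylpiperidin-1-yl on an aromatic carbon. Among the measured compounds shown here, no measured pair shows the size of such a change, so only a modest fall in this assay, with wide uncertainty, is expected: the estimated step is a 1.8-fold lower number from compound 1 to compound 3 (0.25 log units; within the scatter). For compound 3 the expected value is 3000 ng.h/mL, with an estimated range of 800 ng.h/mL to 10000 ng.h/mL.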

Compound 3, area under the concentration-time curve: 13200 ng.h/mL
The estimate for compound 3 lay 4.4-fold (0.64 log units) below the measured number; the whole stated range lies below it.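

At this position, on an aromatic carbon para to a large group, the 4-hydroxy-4-methylpiperidin-1-yl ring is not required for a high number in this assay. Dimethylcarbamoyl, which has no ring and no hydrogen-bond donor, gives a 2.5-fold higher number from compound 1 to compound 3 (0.40 log units; beyond the scatter). This single pair cannot separate the loss of the ring from the loss of the hydroxyl, and no other measurement bears on why the number rose. On these data alone, it remains open whether a primary amide, a carboxylic acid or an unsubstituted piperidine would behave likewise here, and whether the rise would persist with an ethoxy group in place of the methoxy.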